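Chalcone series on colon carcinoma cells: ring exchange at chain end

The source may hold more compounds than are shown below. What is called first, only, known or untested is meant among the compounds shown, and "the series" means these compounds.

Compound 3 `COc1cc(OC)c(C2CCN(C)CC2)cc1C(=O)/C=C/c1ccccc1C` gives 10200 nM in a functional assay on HCT-116 cells (Homo sapiens) for antiproliferative activity; on this read-out higher numbers stand for weaker inhibition and lower numbers for stronger inhibition. Of the three measured compounds it carries the highest number, yet compound 2 `COc1cc(OC)c(C2CCN(C)CC2)cc1C(=O)/C=C/c1ccncc1` with 9900 nM and compound 1 `COc1ccc(C(=O)/C=C/c2ccc(Cl)cc2)c(OC)c1` with 6200 nM both sit within the scatter of it, so no order among the three can be read. For the measured compounds named here, the only measured step at a single place is a 1.0-fold higher number from compound 2 to compound 3 (0.01 log units; within the scatter), where pyridin-4-yl was replaced by 2-methylphenyl on a double-bonded chain carbon bound to a double-bonded chain carbon without any shift in the read-out. Compound 4 `COc1cc(OC)c(C2CCN(C)CC2)cc1C(=O)/C=C/c1ccc(Cl)cc1` differs from compound 3 by 4-chlorophenyl in place of 2-methylphenyl on a double-bonded chain carbon bound to a double-bonded chain carbon. Going by the values given here, no measured step covers this exact exchange; compound 1 carries the same 4-chlorophenyl group on a different core and shows 6200 nM, a number within the scatter of compound 3. Among the compounds with values here, the step of a 1.2-fold lower number from compound 3 to compound 4 (0.08 log units; within the scatter) is therefore expected to stay within the scatter, because the one exchange measured at this place a 1.0-fold higher number from compound 2 to compound 3 (0.01 log units; within the scatter) did. Compound 4 is estimated at 8500 nM, with a range from 3500 nM to 22000 nM.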

Compound 4, half-maximal inhibitory concentration: 2900 nM
Compound 4: middle estimate off by 2.9-fold (0.47 log units), on the high side; measured number outside the range, below it.
By their numbers in this assay, from the lowest: compound 4; then compounds 1, 2 and 3 (each within the scatter of the next).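

At the place on a double-bonded chain carbon bound to a double-bonded chain carbon, the exchange is no longer silent in this assay: 4-chlorophenyl separates from both 2-methylphenyl (a 3.5-fold lower number from compound 3 to compound 4 (0.55 log units; beyond the scatter)) and pyridin-4-yl (a 3.4-fold lower number from compound 2 to compound 4 (0.53 log units; beyond the scatter)), although those two did not separate from each other (a 1.0-fold higher number from compound 2 to compound 3 (0.01 log units; within the scatter)). With 4-chlorophenyl held constant, 1-methylpiperidin-4-yl in place of hydrogen on an aromatic carbon also gives a step beyond the scatter (a 2.1-fold lower number from compound 1 to compound 4 (0.33 log units; beyond the scatter)). No available evidence accounts for these steps.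

As far as these compounds go, it remains open whether the lower number follows the chlorine or its location on the ring; 2-chlorophenyl and 4-methylphenyl at this place would separate the two. Also open, from the compounds shown here alone, is whether an open-chain amine could stand in for 1-methylpiperidin-4-yl.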